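The compounds below may be only part of what the source reports. "The series", "measured", "known", "first", "only" and "open" are said of these compounds alone.

Measured in an ADME assay on liver for metabolic stability, with Liver microsome (Homo sapiens) as the target, using microsomes and NADPH, with a stated time of 30 min, tested at 0.5 uM; on this read-out higher numbers stand for fast clearance and lower numbers for slow clearance:
- Compound 1 `O=C1N(c2ccncc2)CCN1c1cccc2c1cnn2-c1ccccc1F`: 63.3 mL/min/kg
- Compound 2 `O=C1N(Cc2ncco2)CCN1c1cccc2c1cnn2-c1ccccc1F`: < 33.4 mL/min/kg

Compound 2 has only a limit of the assay, not a number: < 33.4 mL/min/kg. Compound 3 `CC(C)(C)OC(=O)N1CCN(c2cccc3c2cnn3-c2ccccc2F)C1=O` is not yet measured and differs from compound 2 in one place: tert-butoxycarbonyl in place of (1,3-oxazol-2-yl)methyl on an amide-type nitrogen in a ring. Going by the values given here, the one measured step at that nitrogen is an at least 1.8-fold lower number from compound 1 to compound 2 (0.27 log units; that floor lies within the scatter). That step did not involve tert-butoxycarbonyl, so it offers only weak guidance on size. A modest rise in this assay is expected, not a fall: an at least 1.4-fold higher number from compound 2 to compound 3 (0.17 log units; that floor lies within the scatter). For compound 3, the estimated clearance is 50 mL/min/kg, with an expected range of 25 mL/min/kg to 105 mL/min/kg.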

Compound 3, clearance: 98.3 mL/min/kg
The estimate for compound 3 lay 2.0-fold (0.29 log units) below the measured number, and the stated range covers the measured number.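

In this assay, tert-butoxycarbonyl in place of (1,3-oxazol-2-yl)methyl on this amide-type nitrogen gives an at least 2.9-fold higher number from compound 2 to compound 3 (0.46 log units; beyond the scatter) and so shows that a change at this position can reach beyond the scatter, which the earlier step did not show. Tert-butoxycarbonyl in place of pyridin-4-yl gives a 1.6-fold higher number from compound 1 to compound 3 (0.19 log units; within the scatter) and leaves compound 1 and compound 3 not told apart. The value of compound 2 is a limit of the assay, not a number: the limit of < 33.4 mL/min/kg in this assay, at which 1 of the 3 values shown sits.

Still open, as far as these compounds go, is whether another group on this nitrogen, such as benzyl or acetyl, would sit with compound 2 or with compound 3.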